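Moving the Hydroxyl Around a Series Without Measurable Activity

A few compounds are considered here, and "the series" means these few. Any claim that something is new, unique, unknown or untested is made for them only; others in the source may bear on it.

Compound 2 `Oc1ccc(-c2cc(-c3ccccc3F)cc(-c3ccccc3O)n2)cc1` is one of three related compounds tested in a functional assay on T47D cells (Homo sapiens) for inhibition; a higher number here means a weaker inhibitor, a lower number a stronger inhibitor. In this assay compound 2 gives > 50000 nM, which is a limit of the assay rather than a number. Compound 1 `Oc1ccccc1-c1cc(-c2ccccc2F)cc(-c2ccccc2O)n1` in this assay gives > 50000 nM, also a limit. Compound 3 `Oc1ccc(-c2cc(-c3cccc(F)c3)cc(-c3ccccc3O)n2)cc1` in this assay gives > 50000 nM, again a limit. All three values sit at the same limit (the limit of > 50000 nM in this assay, at which 3 of the 3 values shown sit), so the step that the two limits leave unreadable from compound 1 to compound 2 and the step that the two limits leave unreadable from compound 2 to compound 3 cannot be read in size or direction.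

Compound 4 `Oc1ccc(-c2cc(-c3ccccc3F)cc(-c3cccc(O)c3)n2)cc1` has not yet been measured. It differs from compound 2 in one place: 3-hydroxyphenyl in place of 2-hydroxyphenyl on an aromatic carbon. Neither measured step shows whether shifting the hydroxyl or the fluorine changes the read-out, because every value sits at the limit (the limit of > 50000 nM in this assay, at which 3 of the 3 values shown sit). Going by the values given here, no step therefore predicts a change for compound 4 beyond the scatter, and the only expectation the three limits support is that compound 4 remains at the limit as well. Compound 4 is therefore expected to give about 60000 nM in this assay, with a range from 20000 nM to 200000 nM. The expected step that the limit leaves unreadable from compound 2 to compound 4 would thus amount to no readable change.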

Compound 4, half-maximal inhibitory concentration: 6370 nM
Compound 4: middle estimate off by 9.4-fold (0.97 log units), on the high side; measured number outside the range, below it.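

Moving the hydroxyl on the ring placed next to the ring nitrogen gives the first readable change in the series: in this assay there is an at least 7.8-fold lower number from compound 2 to compound 4 (0.89 log units; beyond the scatter). Going by these compounds alone, the two groups have the same atoms and differ only in where the hydroxyl stands, so this position responds to the location of the hydroxyl alone, which the earlier steps, all unreadable, could not show. All three compounds that stay at the limit carry 2-hydroxyphenyl at this place, and compound 4, with 3-hydroxyphenyl there, is the only one that leaves it: the limit of > 50000 nM in this assay, at which 3 of the 4 values shown sit.

The true size of the step remains unknown, as compound 2 gives only a limit, and the compounds shown do not tell whether the same shift would count with 3-fluorophenyl in place of 2-fluorophenyl. They also leave open whether a 4-hydroxyphenyl group at this place would go further, and whether the hydroxyl itself is needed there or a 3-aminophenyl or 3-methoxyphenyl group would serve as well.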